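The source may report more compounds than this note shows. Statements on the series, on what has been measured and on what is new or still open speak of the compounds shown alone.

Within the data shown here, compound 1 `O=C(CCCNC(=O)c1cc(C(F)(F)F)cc(C(F)(F)F)c1)Nc1ccc(Cl)cc1` is one of three compounds measured in a functional assay on PC-3 cells (Homo sapiens) for inhibition, read by WST assay, tested at 100 uM (a higher number here means a stronger effect of the compound at the concentration tested, a lower number a weaker effect), and in that test compound 1 gives 12%, the lowest of the three numbers. Compound 2 `O=C(CONC(=O)c1cccc(C(F)(F)F)c1)Nc1ccc(Cl)cc1` gives 58% in this assay, and compound 3 `O=C(CONC(=O)c1ccc(C(F)(F)F)cc1)Nc1ccc(Cl)cc1` gives 56%; both stand beyond the scatter above compound 1, compound 3 being the nearer of the two and compound 2 the further. Among the measured compounds shown here, no step between measured compounds that differ in only one place is available, as compounds 2 and 3 differ from compound 1 in more than one respect. Compound 4 `O=C(NCCCNc1ccc(Cl)cc1)c1cc(C(F)(F)F)cc(C(F)(F)F)c1` has not yet been measured. It differs from compound 1 as follows: (4-chlorophenyl)amino in place of (4-chlorophenyl)carbamoyl on a saturated chain carbon, three bonds along the chain from an amide-type nitrogen. There is no measured change of this kind to draw on. The expected step of a number 6 percentage points higher from compound 1 to compound 4 (within the scatter) is small, most likely within the scatter, with a slight lean upward. The lean is upward because compound 1 itself sits low at 12%, leaving more room above than below. Compound 4 is therefore estimated at 18% in this assay, with a range from 2% to 45%.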

Compound 4, a percentage reported as inhibition, at one concentration (the size of the read-out at that concentration, not a potency): 11%
Beside the measured number, compound 4's estimate is 7 percentage points above it, within the range that was stated.
By their numbers in this assay, from the lowest: compounds 4 and 1 (each within the scatter of the next); then compounds 3 and 2 (each within the scatter of the next).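

Among these compounds, the first comparison in one place, (4-chlorophenyl)amino in place of (4-chlorophenyl)carbamoyl on a saturated chain carbon, three bonds along the chain from an amide-type nitrogen, comes out in this assay as a number 1 percentage points lower from compound 1 to compound 4 (within the scatter). At this position, then, the carbonyl of the (4-chlorophenyl)carbamoyl group can be removed without a readable change, although the level held is a low one, with compound 1 at 12%. Nothing at hand explains why the two groups read alike.

Going by these compounds, it remains open whether another group at this place, such as a carboxylic acid, an amine or a longer chain, would move the number beyond the scatter. On these data alone, it is also open whether the same change would stay this small on a different core.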